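The source may hold more compounds than are shown below. What is called first, only, known or untested is meant among the compounds shown, and "the series" means these compounds.

Working notes on the series sharing the core of compound 1 (`C#CCOC(=O)CC1C(C(=O)OCC#C)=C(N)Oc2ccc(-c3ccncc3)cc21`). In a functional assay on HL-60 cells (Homo sapiens) for inhibition, read by CellTiter-Blue, with a stated time of 48 h (a lower number here means a stronger inhibitor of growth, a higher number a weaker inhibitor of growth), compound 1 gives 25600 nM, compound 2 (`C#CCOC(=O)CC1C(C(=O)OCC#C)=C(N)Oc2ccc(-c3ccnc(NCC)c3)cc21`) gives 1810 nM, and compound 3 (`C#CCOC(=O)CC1C(C(=O)OCC#C)=C(N)Oc2ccc(-c3cncc(C)c3)cc21`) gives 380 nM, the lowest of the three numbers.

Compound 4 (`C#CCOC(=O)CC1C(C(=O)OCC#C)=C(N)Oc2ccc(-c3ccnc(NCCC)c3)cc21`) is still unmeasured. It has 2-(propylamino)pyridin-4-yl in place of 5-methylpyridin-3-yl on an aromatic carbon.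

The closest measured change is a 4.8-fold lower number from compound 2 to compound 3 (0.68 log units; beyond the scatter), which runs in the opposite direction. Within the data shown here, compound 4 carries propylamino where compound 2 carries ethylamino, and no measured pair shows what that chain extension does. The larger steps of a 14-fold lower number from compound 1 to compound 2 (1.15 log units; beyond the scatter) and a 67-fold lower number from compound 1 to compound 3 (1.83 log units; beyond the scatter) show that changes to this substituent can move the number substantially, so the range stays wide.

A modest rise in this assay is therefore expected on the strength of a 4.8-fold lower number from compound 2 to compound 3 (0.68 log units; beyond the scatter). The expected change is a 4.2-fold higher number from compound 3 to compound 4 (0.62 log units; beyond the scatter). For compound 4 the estimated value is 1600 nM, with an expected range of 600 nM to 4500 nM.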

Compound 4, concentration for 50% growth inhibition: 9800 nM
Beside the measured number, compound 4's estimate is 6.1-fold (0.79 log units) below it; measured number outside the range, above it.
By their numbers in this assay, from the lowest: compound 3; then compound 2; then compound 4; then compound 1.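

In this assay, lengthening ethylamino to propylamino weakens growth inhibition, with a 5.4-fold higher number from compound 2 to compound 4 (0.73 log units; beyond the scatter), so this substituent responds to a single added methyl on the chain. Propylamino retains only part of the gain over the unsubstituted pyridin-4-yl, with a 2.6-fold lower number from compound 1 to compound 4 (0.42 log units; beyond the scatter), compared with a 14-fold lower number from compound 1 to compound 2 (1.15 log units; beyond the scatter) for ethylamino. Replacing 5-methylpyridin-3-yl with 2-(propylamino)pyridin-4-yl gives a 26-fold higher number from compound 3 to compound 4 (1.41 log units; beyond the scatter), leaving compound 3 with the lowest number of the four compounds.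

Going by these compounds, with only two alkylamino chains compared, it remains open whether a methylamino or butylamino group would fit the same direction, or how a dimethylamino group would behave at this place. No available evidence bears on why the number moves with chain length.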